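Swapping the Furan Amide for a Urea on a Shared Core

The source may report more compounds than this note shows. Statements on the series, on what has been measured and on what is new or still open speak of the compounds shown alone.

Of the compounds shown here, three built on one shared core have been tested in an assay on CHO cells for displacement of a labelled ligand from adenosine receptor A1 (Homo sapiens), tested at 10 uM; on this read-out higher numbers stand for more inhibition at the one concentration tested (going by the name of the read-out) and lower numbers for less inhibition. Compound 1 `COc1ccc(C(=O)Nc2nn(-c3ccccc3)c(=O)c3ccccc23)cc1` gives 0%, compound 2 `COc1ccccc1NC(=O)Nc1nn(-c2ccccc2)c(=O)c2ccccc12` gives 0%, and compound 3 `O=C(Nc1nn(-c2ccccc2)c(=O)c2ccccc12)c1ccco1` gives 23%. Compound 3 therefore stands highest of the three, since a number 23 percentage points higher from compound 1 to compound 3 (beyond the scatter) and a number 23 percentage points higher from compound 2 to compound 3 (beyond the scatter), whereas no change at the digits printed from compound 1 to compound 2 (within the scatter).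

Compound 4 `Cc1ccccc1NC(=O)Nc1nn(-c2ccccc2)c(=O)c2ccccc12` awaits measurement. Its difference from compound 3 is (2-methylphenyl)amino in place of furan-2-yl on a carbonyl carbon. The measured step that bears on this runs the other way: a number 23 percentage points higher from compound 2 to compound 3 (beyond the scatter), which shows the furan-2-yl amide lifting the number above the (2-methoxyphenyl)amino urea. Compound 4 reverses that move, going back to a urea, now carrying (2-methylphenyl)amino instead of (2-methoxyphenyl)amino. Because compound 2 gives 0% and compound 1 gives 0%, the return to a urea is expected to undo most of the gain. The expected step is a number 20 percentage points lower from compound 3 to compound 4 (beyond the scatter), downward. Compound 4 is estimated to give 3% in this assay, within a range from 0% to 15%.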

Compound 4, a percentage reported as inhibition, at one concentration (the size of the read-out at that concentration, not a potency): 20%
Estimate against measurement, compound 4: 17 percentage points below, outside the stated range (above it).
By their numbers in this assay, from the lowest: compounds 1 and 2 (each within the scatter of the next); then compounds 4 and 3 (each within the scatter of the next).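

The urea on this carbonyl carbon does not by itself silence the read-out: in this assay there is a number 3 percentage points lower from compound 3 to compound 4 (within the scatter) and so the furan-2-yl amide and the (2-methylphenyl)amino urea cannot be told apart. What separates the two ureas is one small swap, methyl in place of methoxy on an aromatic carbon, which gives a number 20 percentage points higher from compound 2 to compound 4 (beyond the scatter) and shows that the outcome for a urea here depends on the group carried by its aromatic ring. The (2-methylphenyl)amino group also compares well with 4-methoxyphenyl on the same carbonyl carbon, with a number 20 percentage points higher from compound 1 to compound 4 (beyond the scatter) as the step.

Whether a chlorine or an ethyl group in place of that methyl would read like methyl or like methoxy stays open, as does the behaviour of these compounds at other concentrations. Nothing shown here explains why methyl and methoxy read differently in this position.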